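This account rests on a few compounds, and the source may have more. Where it says the series, first, only, none or still open, it means among the compounds named here.

Compound 1 `Cc1cccc(NC(=O)CN2CCN(c3ccc(Cl)cn3)CC2)c1` was tested in an assay on cells for antagonist activity at D(4) dopamine receptor (Homo sapiens), read by luminescence and beta-arrestin recruitment, with a stated time of 90 min (on this read-out lower numbers stand for stronger inhibition and higher numbers for weaker inhibition), and gave 7780 nM, the highest of the two numbers recorded so far. Its nearest neighbour is compound 2 `Cc1cccc(NC(=O)CN2CCN(c3ncccn3)CC2)c1`, which in the same assay gave 197 nM; that change, a 39-fold lower number from compound 1 to compound 2 (1.60 log units; beyond the scatter), sits on the amine nitrogen in the ring, not on the amide-type nitrogen. The untested compound 3 `O=C(CN1CCN(c2ccc(Cl)cn2)CC1)Nc1cncnc1` differs from compound 1 at the other end of the molecule: pyrimidin-5-yl in place of 3-methylphenyl on an amide-type nitrogen. Going by the values given here, no measured step touches the group on the amide-type nitrogen, so the single known step from compound 1 to compound 2 offers no direct guide, and the change is best treated as uncharted. Compound 3 is therefore expected to remain close to compound 1, with a step of a 1.3-fold higher number from compound 1 to compound 3 (0.11 log units; within the scatter) anticipated to stay within the scatter, and its estimated value is 10000 nM with a range from 3000 nM to 40000 nM.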

Compound 3, half-maximal inhibitory concentration: > 100000 nM
Compound 3 gave a limit, no number; the forecaster's own chance of this, stated with the estimate: 30%; middle value at least 10-fold (1.00 log units) away from the limit.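

With pyrimidin-5-yl in place of 3-methylphenyl on the amide-type nitrogen, this assay shows an at least 12-fold higher number from compound 1 to compound 3 (1.10 log units; beyond the scatter). This shows that the group on the amide-type nitrogen matters in this series, whereas the earlier step had shown only that the group on the amine nitrogen in the ring does, and that this change moves the number upward from a compound that already stood high. The result for compound 3 is a limit of the assay and not a number: the limit of > 100000 nM in this assay, at which 1 of the 3 values shown sits.

The compounds shown leave open whether the rise follows the two ring nitrogens of pyrimidin-5-yl or the absence of the methyl group, a question that a plain phenyl or a pyridin-3-yl group on the amide-type nitrogen would address. Also open, on these data alone, is whether pyrimidin-5-yl has a comparable effect when the pyrimidin-2-yl group of compound 2 is on the amine nitrogen in the ring.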